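From compound 3 to compound 4: removing the methylcarbamoyl group

The source may hold more compounds than are shown below. What is called first, only, known or untested is meant among the compounds shown, and "the series" means these compounds.

Of the compounds shown here, three have been read in an ADME assay on CEM-SS cells (Homo sapiens) for cytotoxicity, read by XTT assay, with a stated time of 6 days; on this read-out lower numbers stand for higher toxicity in this test and higher numbers for lower toxicity in this test. Compound 1 `CCCC(=O)OCSc1ccccc1C(=O)NC1(C(N)=O)CCCC1` gives > 100 uM, which is a limit of the assay. Compound 3 `CCCC(=O)OCSc1ccccc1C(=O)NCC(=O)NC` gives > 100 uM, which is also a limit. Among the compounds with values here, compound 2 `CCCC(=O)OCSc1ccccc1C(=O)NCCCCNC(C)=O` gives 17.4 uM, the only actual number so far. Compound 3 therefore has no number of its own and stands at the limit, as the limit of > 100 uM in this assay, at which 2 of the 3 values shown sit, shows.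

The next structure is compound 4 `CCCC(=O)OCSc1ccccc1C(=O)NC`. The change is hydrogen in place of methylcarbamoyl on a saturated chain carbon bound to an amide-type nitrogen.

Two measured steps can be read: an at least 5.7-fold lower number from compound 1 to compound 2 (0.75 log units; beyond the scatter), and an at least 5.7-fold higher number from compound 2 to compound 3 (0.75 log units; beyond the scatter). Both turn on the side chain of compound 2, and compound 4 does not carry that chain. The third step, a step that the two limits leave unreadable from compound 1 to compound 3, gives no size. Within the data shown here, these steps offer no precedent for a fall in this assay when the side chain is simply cut back, so no step beyond the scatter is expected. The expected step is a number no higher from compound 3 to compound 4 (the limit leaves the size open), and the reading may again be only a limit. For compound 4 the estimated value is 100 uM, with an expected range of 40 uM to 250 uM.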

Compound 4, half-maximal toxic concentration: 5.7 uM
Compound 4: the middle estimate sits 18-fold (1.24 log units) above what was measured; the measured number lies below the stated range.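

Hydrogen in place of methylcarbamoyl is the first change in this series that lowers the number without a longer chain entering: in this assay it gives an at least 17-fold lower number from compound 3 to compound 4 (1.24 log units; beyond the scatter). The plain methyl on the amide-type nitrogen also falls short of both other side chains, with an at least 17-fold lower number from compound 1 to compound 4 (1.24 log units; beyond the scatter) and with a 3.1-fold lower number from compound 2 to compound 4 (0.48 log units; beyond the scatter), so a low number in this series does not require the 4-acetamidobutyl chain. Among the four side chains shown, the two that sit at the limit both carry a carbamoyl-type group on the saturated chain carbon bound to the amide-type nitrogen, while the other two do not, and no compound shown goes against this split.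

Going by these compounds, the full size of the steps that start from the two limit compounds stays open, and the step between those two compounds cannot be read, because neither has a number of its own: the limit of > 100 uM in this assay, at which 2 of the 4 values shown sit. Whether a carboxylic acid, an amine or a simple ethyl group on that same carbon would keep the number at the limit or lower it also stays open.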